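Replacing the hydroxy hydrogen of compound 1

The source may report more compounds than this note shows. Statements on the series, on what has been measured and on what is new or still open speak of the compounds shown alone.

- compound 1 `COc1cc(-c2cc(=O)c3ccc(O)cc3o2)cc(OC)c1OC`: 51400 nM
- compound 2 `COc1ccc(-c2cc(=O)c3ccc(OCCCCCCN4CCC(CCO)CC4)cc3o2)cc1`: 50400 nM

Both numbers come from a functional assay for inhibition, read by fluorescence and spectrophotometry, with a stated time of 30 h; on this read-out lower numbers stand for stronger inhibition and higher numbers for weaker inhibition. Compound 1 stands level with compound 2, since their values lie within the usual scatter of each other, and neither can be called the better inhibitor.

The next compound, compound 3 `COc1cc(-c2cc(=O)c3ccc(OCCCN4CCC(C)CC4)cc3o2)cc(OC)c1OC`, keeps the core of compound 1 and changes it in one place. A hydroxy group becomes a 3-(4-methylpiperidin-1-yl)propoxy group (3-(4-methylpiperidin-1-yl)propyl in place of hydrogen on an oxygen on an aromatic ring), which means 3-(4-methylpiperidin-1-yl)propyl in place of hydrogen on an oxygen on an aromatic ring.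

Going by the values given here, no two measured compounds differ in just one place, so the data hold no direct precedent for this change, and any forecast must stay loose. A change of this size could move the number either way, but a moderate move toward stronger inhibition in this assay seems somewhat more likely. The expected change is a 2.6-fold lower number from compound 1 to compound 3 (0.41 log units; beyond the scatter), and this estimate carries wide uncertainty. For compound 3 the estimated value is 20000 nM, with an expected range of 3000 nM to 80000 nM.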

Compound 3, half-maximal inhibitory concentration: 41800 nM
Compound 3: middle estimate off by 2.1-fold (0.32 log units), on the low side, within the range that was stated.
By their numbers in this assay, from the lowest: compounds 3, 2 and 1 (each within the scatter of the next).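

In this assay, placing a 3-(4-methylpiperidin-1-yl)propyl group in place of hydrogen on an oxygen on an aromatic ring gives a 1.2-fold lower number from compound 1 to compound 3 (0.09 log units; within the scatter) in this one-place comparison, so compound 1 and compound 3 stand level. This is the only direct reading of this position among the compounds shown, and it suggests that inhibition at this modest level does not depend on keeping the free hydroxy group: a group of 10 heavy atoms, including a six-membered non-aromatic ring, can sit on that oxygen and the result stays within the usual scatter. No supporting data bear on why the two compounds stand level.

A single step cannot show whether this level result is specific to the 3-(4-methylpiperidin-1-yl)propyl group or would also hold for other groups on the same oxygen, such as a simple methyl ether, or a morpholine ring or dimethylamino group at the end of the propoxy chain. It also leaves open whether any group at this position can move inhibition beyond the scatter in either direction.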